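Benzyl thioether variation on the shared sulfonylguanidine core

The compounds below may be only part of what the source reports. "The series", "measured", "known", "first", "only" and "open" are said of these compounds alone.

Measured so far in a functional assay on MCF7 cells (Homo sapiens) for antiproliferative activity, read by MTT assay, with a stated time of 72 h; on this read-out higher numbers stand for weaker inhibition and lower numbers for stronger inhibition:
compound 1 `Cc1cc(S(=O)(=O)/N=C(\N)N/N=C/C#Cc2ccccc2)c(SCc2ccccc2)cc1Cl` gives 24000 nM
compound 2 `Cc1cc(S(=O)(=O)/N=C(\N)N/N=C/C#Cc2ccccc2)c(SCc2ccccc2C)cc1Cl` gives 13000 nM
compound 3 `C/C(C#Cc1ccccc1)=N\N/C(N)=N/S(=O)(=O)c1cc(C)c(Cl)cc1SCc1ccccc1C` gives 150000 nM

Compound 2 gives the lowest of the three numbers, but compound 1 sits within the scatter of it, so the two cannot be ordered; only compound 3 stands apart, with a 12-fold higher number from compound 2 to compound 3 (1.06 log units; beyond the scatter).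

Compound 4 `Cc1cc(S(=O)(=O)/N=C(\N)N/N=C/C#Cc2ccccc2)c(SCc2ccc(C(F)(F)F)cc2)cc1Cl` is not yet measured. Relative to compound 2 the change is 4-(trifluoromethyl)phenyl in place of 2-methylphenyl on a saturated chain carbon bound to a sulfur. Among the compounds with values here, of the measured steps, only the one on the same benzyl thioether bears on this: a 1.8-fold lower number from compound 1 to compound 2 (0.27 log units; within the scatter). That step was within the scatter, so swapping substituents on this aryl has so far left the read-out unchanged. The large step from compound 2 to compound 3 sits on the hydrazone carbon, a different place, and says nothing about the benzyl thioether.

For compound 4 no step beyond the scatter is therefore expected, with a 1.2-fold higher number from compound 2 to compound 4 (0.06 log units; within the scatter) as the central guess. Compound 4 is estimated at 15000 nM, with a range from 5000 nM to 45000 nM; the range is kept wide, as a single within-scatter step is thin ground for any aryl change.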

Compound 4, half-maximal inhibitory concentration: 105000 nM
For compound 4 the middle estimate is 7.0-fold (0.85 log units) below the measured one, and the stated range ends below it.
By their numbers in this assay, from the lowest: compounds 2 and 1 (each within the scatter of the next); then compounds 4 and 3 (each within the scatter of the next).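

In this assay the aryl on the benzyl thioether is no longer silent: a 4.4-fold higher number from compound 1 to compound 4 (0.64 log units; beyond the scatter) when trifluoromethyl replaces hydrogen on the aromatic carbon of the plain benzyl, and an 8.1-fold higher number from compound 2 to compound 4 (0.91 log units; beyond the scatter) when 4-(trifluoromethyl)phenyl replaces 2-methylphenyl on the saturated chain carbon bound to sulfur. The earlier methyl step stayed within the scatter, so this place does respond to substitution, and the response depends on the group that enters, with both steps pointing to higher numbers and so to weaker inhibition. Nothing at hand accounts for the size of these steps or ties them to any property of the trifluoromethyl group.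

The step from the 2-methylbenzyl compound changes both the substituent and its place on the ring, so these compounds cannot separate the two; a 4-methylbenzyl or a 2-(trifluoromethyl)benzyl thioether on the same core would settle this. Also open, from the compounds shown here alone, is whether the higher number holds for other groups on this ring, such as a 4-amino or 4-carboxylic acid benzyl, or for a longer chain between the sulfur and the ring.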